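A Smaller Group on the Same Amine Nitrogen

The source may report more compounds than this note shows. Statements on the series, on what has been measured and on what is new or still open speak of the compounds shown alone.

Among the measured compounds shown here, in an ADME assay on WISH cells (Homo sapiens) for cytotoxicity, read by MTT assay, with a stated time of 48 h (on this read-out higher numbers stand for weaker inhibition and lower numbers for stronger inhibition), compound 1 `CCOC(=O)C1=C(N/C=N/c2cccnc2Cl)Nc2[nH]nc(C)c2C1c1ccc(N(C)C)cc1` gives 60100 nM and compound 2 `CCOC(=O)C1=C(NN=C(C(C)=O)C(C)=O)Nc2[nH]nc(C)c2C1c1ccc(N(C)C)cc1` gives 58700 nM, so compound 2 stands level with the only other measured compound, within the scatter. Compound 3 `CCOC(=O)C1=C(NN=C(C#N)C#N)Nc2[nH]nc(C)c2C1c1ccc(N(C)C)cc1` keeps the shared core and differs from compound 2 in one place, on an amine nitrogen: a group of 6 heavy atoms (3 carbon, 3 nitrogen; no ring) in place of a group of 8 heavy atoms (5 carbon, 1 nitrogen, 2 oxygen; no ring), on an amine nitrogen. For the measured compounds named here, one measured step bears on this change, since it falls on that same amine nitrogen. That step, a 1.0-fold lower number from compound 1 to compound 2 (0.01 log units; within the scatter), lies within the scatter, although a group with a six-membered aromatic ring gave way to a group with no ring. A single step is thin evidence, but on its showing no shift beyond the scatter is expected in this assay, and the estimated move is a 1.2-fold lower number from compound 2 to compound 3 (0.07 log units; within the scatter). Compound 3 is therefore expected at 50000 nM, with an estimated range of 20000 nM to 110000 nM.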

Compound 3, half-maximal inhibitory concentration: 45300 nM
For compound 3 the middle estimate is 1.1-fold (0.04 log units) above the measured one; the measured number falls inside the stated range.
By their numbers in this assay, from the lowest: compounds 3, 2 and 1 (each within the scatter of the next).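

In this assay, exchanging the open-chain carbonyl group for the open-chain nitrile group leaves the two compounds level (a 1.3-fold lower number from compound 2 to compound 3 (0.11 log units; within the scatter)), and so does exchanging the ring-bearing, chlorine-containing group for that same nitrile group (a 1.3-fold lower number from compound 1 to compound 3 (0.12 log units; within the scatter)). The earlier comparison rested on one pair, whereas this position now carries three different groups, and none of the steps among them goes beyond the scatter, whether a ring is present or not and whether the group holds chlorine, carbonyl or nitrile. Nothing measured here explains why these groups read alike.

As far as these compounds go, whether a plain methyl, a carboxylic acid or an amine on this nitrogen would shift the number beyond the scatter remains open. Changes elsewhere on the shared core also remain untested by these compounds, which all keep it unchanged.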